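Shortening the chain and swapping the cyanoguanidine end group

The source may hold more compounds than are shown below. What is called first, only, known or untested is meant among the compounds shown, and "the series" means these compounds.

For the measured compounds named here, compound 1 `C/N=C(/NC#N)NCCCCCn1nc(-c2ccccc2)ccc1=O` is one of two compounds measured in a functional assay on the whole organism (stomach) with Rattus norvegicus as the target; on this read-out lower numbers stand for an effect already at smaller amounts and higher numbers for an effect only at larger amounts of compound. In this assay, going by the values given here, compound 1 gives 100 mg/kg, the only number recorded. Compound 2 `C/N=C(/NC#N)NCCCCCn1nc(-c2ccccc2)cc(C)c1=O` reaches only > 100 mg/kg in this assay, which is a limit of the assay and not a number. The step of a number no lower from compound 1 to compound 2 (the limit leaves the size open) is therefore of unreadable size, and it rests on (the limit of > 100 mg/kg in this assay, at which 1 of the 2 values shown sits).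

Compound 3 `C/N=C(\S)NCCCCn1nc(-c2ccccc2)ccc1=O` differs from compound 1 by a group of 5 heavy atoms (2 carbon, 2 nitrogen, 1 sulfur; no ring) in place of a group of 8 heavy atoms (4 carbon, 4 nitrogen; no ring), on a saturated chain carbon, four bonds along the chain from an aromatic nitrogen. Among the compounds with values here, none of the measured steps touches this part of the molecule, and the single step recorded gives no size to lean on. No change beyond the scatter is therefore expected, so the step of no change at the digits printed from compound 1 to compound 3 (within the scatter) is estimated as flat. For compound 3 a value of 100 mg/kg is expected, within a range from 30 mg/kg to 300 mg/kg.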

Compound 3, dose for half-maximal effect: 28.9 mg/kg
For compound 3 the middle estimate is 3.5-fold (0.54 log units) above the measured one; measured number below the stated range.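

At this position, on a saturated chain carbon, four bonds along the chain from an aromatic nitrogen, the exchange of the end group gives a 3.5-fold lower number from compound 1 to compound 3 (0.54 log units; beyond the scatter) in this assay. This is the first step among the compounds shown whose size can be read, and it shows that this part of the molecule can move the read-out beyond the scatter. Nothing measured here gives a reason for this step.

The exchange alters the chain and the end group in a single move, so the compounds shown do not tell which of the two carries the step. Also open, from the compounds shown here alone, is how a urea end group, an amine or a longer chain would read at this place, and whether a methyl on the aromatic carbon would behave on compound 3 as it does on compound 1.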